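Swapping a Hydroxycyclohexylmethyl Urea for a Hydroxyethyl Piperidine

The compounds below may be only part of what the source reports. "The series", "measured", "known", "first", "only" and "open" are said of these compounds alone.

Compound 3 `O=C(NC[C@@H]1CCCC[C@H]1O)NC1CCN(Cc2ccn(-c3ccc(C(F)(F)F)cc3)c2)CC1` holds the second highest of three numbers in an assay on HEK293 cells for displacement of a labelled ligand from melanin-concentrating hormone receptor 1 (Homo sapiens) (a higher number here means a weaker inhibitor, a lower number a stronger inhibitor), where compound 3 gives 46 nM. Compound 2 `O=C(NC1CCN(Cc2ccn(-c3ccc(C(F)(F)F)cc3)c2)CC1)N1CCCC1Cc1cccnc1` gives 26 nM, and compound 1 `O=C(NC1CCN(Cc2ccn(-c3ccc(C(F)(F)F)cc3)c2)CC1)NS(=O)(=O)c1ccc(F)cc1` gives 617 nM. Both a 24-fold lower number from compound 1 to compound 2 (1.38 log units; beyond the scatter) and a 13-fold lower number from compound 1 to compound 3 (1.13 log units; beyond the scatter) are large gains over the sulfonyl compound, whereas a 1.8-fold higher number from compound 2 to compound 3 (0.25 log units; within the scatter) stays within the scatter although it exchanges a cyclic amine on the carbonyl carbon for an open amide-type nitrogen. Compound 4 `O=C(NC1CCN(Cc2ccn(-c3ccc(C(F)(F)F)cc3)c2)CC1)N1CCCCC1CCO` differs from compound 3 by 2-(2-hydroxyethyl)piperidin-1-yl in place of ((2-hydroxycyclohexyl)methyl)amino on a carbonyl carbon. For the measured compounds named here, the only step that bears on this change is the one from compound 2 to compound 3, and it lies within the scatter. Compound 4 is therefore expected to show a 1.2-fold lower number from compound 3 to compound 4 (0.06 log units; within the scatter), nothing beyond the scatter. The estimate for compound 4 is 40 nM, between 13 nM and 120 nM.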

Compound 4, half-maximal inhibitory concentration: 39 nM
The estimate for compound 4 lay 1.0-fold (0.01 log units) above the measured number; low and high end bracket the measured number.
By their numbers in this assay, from the lowest: compounds 2, 4 and 3 (each within the scatter of the next); then compound 1.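

In this assay, the exchange puts a six-membered ring with 1 hetero atom, 1 hydrogen-bond donor and no defined stereocentres in place of a carbon-only ring with 2 hydrogen-bond donors and 2 defined stereocentres, yet a 1.2-fold lower number from compound 3 to compound 4 (0.07 log units; within the scatter) stays within the scatter. With a 1.5-fold higher number from compound 2 to compound 4 (0.18 log units; within the scatter) also within the scatter and a 16-fold lower number from compound 1 to compound 4 (1.20 log units; beyond the scatter) large, a third group on this carbonyl carbon separates from the sulfonyl compound but not from the other two. No measurement given here explains this. Going by these compounds, what a 2-ethylpiperidin-1-yl or a 2-(2-methoxyethyl)piperidin-1-yl would give at this place remains open, so the part played by the hydroxyl is unresolved.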